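Trimming the chain of compound 1

The source may hold more compounds than are shown below. What is called first, only, known or untested is meant among the compounds shown, and "the series" means these compounds.

In a functional assay on K562 cells (Homo sapiens) for inhibition, read by fluorescence, with a stated time of 72 h (a lower number here means a stronger inhibitor of growth, a higher number a weaker inhibitor of growth), compound 1 (`CCCCCCn1cnc2c(Nc3ccc(Cl)cc3)nc(N[C@H]3CC[C@H](N)CC3)nc21`) gives 2100 nM and compound 3 (`CCCCCCn1cnc2c(Nc3cccc(Cl)c3)nc(N[C@H]3CC[C@H](N)CC3)nc21`) gives 2300 nM, so the two stand level within the scatter. Compound 2 (`CCCCCCn1cnc2c(Nc3ccc(O)cc3)nc(N[C@H]3CC[C@H](N)CC3)nc21`) sits higher at 5400 nM (a 2.6-fold higher number from compound 1 to compound 2 (0.41 log units; beyond the scatter)). Compound 4 (`CCCCn1cnc2c(Nc3ccc(Cl)cc3)nc(N[C@H]3CC[C@H](N)CC3)nc21`) has a shorter chain than compound 1: hydrogen in place of ethyl on a saturated chain carbon, four bonds along the chain from an aromatic nitrogen. Going by the values given here, no measured step touches this chain. The nearest guides are changes on the phenyl group, one within the scatter (a 1.1-fold higher number from compound 1 to compound 3 (0.04 log units; within the scatter)) and the other modest (a 2.3-fold lower number from compound 2 to compound 3 (0.37 log units; beyond the scatter)). Only a small upward step, probably within the scatter, is expected (a 1.3-fold higher number from compound 1 to compound 4 (0.12 log units; within the scatter)). For compound 4 the estimated value is 2800 nM (1200 nM to 6500 nM).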

Compound 4, concentration for 50% growth inhibition: 2700 nM
Compound 4: the middle estimate sits 1.0-fold (0.02 log units) above what was measured; measured number inside the range.
By their numbers in this assay, from the lowest: compounds 1, 3, 4 and 2 (each within the scatter of the next, the first and the last beyond it).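

Hydrogen in place of ethyl on a saturated chain carbon, four bonds along the chain from an aromatic nitrogen, gives a 1.3-fold higher number from compound 1 to compound 4 (0.11 log units; within the scatter) in this assay, the only measured step on this chain. At this position, the shorter butyl chain of compound 4 therefore stands level with the longer chain of compound 1, and the change in chain length is not resolved from the scatter. Nothing available explains this result.

Going by these compounds, whether a much shorter chain such as methyl keeps this level stays open. So does the effect of a longer chain, or of an amine or carboxylic acid at the chain end.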